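Replacing the furoate ester of compound 2 with formyl

The compounds below may be only part of what the source reports. "The series", "measured", "known", "first", "only" and "open" are said of these compounds alone.

Measured so far in an ADME assay on HepG2 2.2.15 cells (Homo sapiens) for cytotoxicity, read by MTT assay; on this read-out higher numbers stand for lower toxicity in this test and lower numbers for higher toxicity in this test
- Compound 1 `C=C1CC[C@@H]2[C@](C)(COC(=O)/C=C/c3cccc(OC)c3)[C@H](O)CC[C@@]2(C)[C@@H]1/C=C/C1=CCOC1=O` gives > 1970000 nM which is a limit
- Compound 2 `C=C1CC[C@@H]2[C@](C)(COC(=O)c3ccco3)[C@H](O)CC[C@@]2(C)[C@@H]1/C=C/C1=CCOC1=O` gives 92000 nM
- Compound 3 `C=C1CC[C@@H]2[C@](C)(COC(=O)c3ccco3)[C@H](OC(=O)c3ccco3)CC[C@@]2(C)[C@@H]1/C=C/C1=CCOC1=O` gives 1110000 nM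

Compound 2 carries the lower of the two exact numbers, and no value in the series lies beneath it. Compound 4 `C=C1CC[C@@H]2[C@](C)(C=O)[C@H](O)CC[C@@]2(C)[C@@H]1/C=C/C1=CCOC1=O` differs from compound 2 by formyl in place of (((furan-2-yl)carbonyl)oxy)methyl on a saturated ring carbon with formyl in place of (((furan-2-yl)carbonyl)oxy)methyl on a saturated ring carbon.

Within the data shown here, two measured steps bear on this change, both large. Furan-2-yl in place of 2-(3-methoxyphenyl)ethenyl on a carbonyl carbon gave one (an at least 21-fold lower number from compound 1 to compound 2 (1.33 log units; beyond the scatter)). (Furan-2-yl)carbonyl in place of hydrogen on an oxygen gave the other (a 12-fold higher number from compound 2 to compound 3 (1.08 log units; beyond the scatter)). Each leaves compound 2 at the low end, yet neither removes the ester, so they guide direction better than size. A higher number is expected in this assay, by less than either measured step. The estimated move is a 2.2-fold higher number from compound 2 to compound 4 (0.34 log units; beyond the scatter) and it remains uncertain. The estimated value for compound 4 is 200000 nM (expected range 50000 nM to 900000 nM).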

Compound 4, half-maximal cytotoxic concentration: 122000 nM
For compound 4 the middle estimate is 1.6-fold (0.21 log units) above the measured one, within the range that was stated.
By their numbers in this assay, from the lowest: compounds 2 and 4 (each within the scatter of the next); then compound 3. At a limit, above all of these: compound 1.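

In this assay the step is a 1.3-fold higher number from compound 2 to compound 4 (0.12 log units; within the scatter) and comes with formyl in place of (((furan-2-yl)carbonyl)oxy)methyl on a saturated ring carbon. Among these compounds, compound 2 and compound 4 therefore cannot be told apart here, so the furan-2-yl ring and the ester on this carbon are not required for a number in this range, whereas the earlier compounds showed only edits that kept an ester at this position. Nothing shown accounts for this outcome.

Still open, as far as these compounds go, is whether other groups on this carbon would read the same: a hydroxymethyl, a carboxylic acid or an amine would test how far the position stays this flat. Also open, from the compounds shown here alone, is whether (furan-2-yl)carbonyl on the hydroxy oxygen of compound 4 would repeat a 12-fold higher number from compound 2 to compound 3 (1.08 log units; beyond the scatter) in the presence of formyl.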